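Adding a second methoxy group to compound 3

The compounds below may be only part of what the source reports. "The series", "measured", "known", "first", "only" and "open" are said of these compounds alone.

Compound 1 `C=CC1=C(C(=O)NCc2ccc(Cl)cc2)C(c2ccc(OC)c(OC)c2)OC1` gives in a functional assay on HeLa cells (Homo sapiens) for cytotoxicity, read by MTT assay, with a stated time of 24 h (a higher number here means a weaker inhibitor, a lower number a stronger inhibitor), only an assay limit, > 100000 nM.
Compound 2 `C=CC1=C(C(=O)NCCC)C(c2ccc(OC)c(OC)c2)OC1` gives in this assay only an assay limit, > 100000 nM.
Compound 3 `C=CC1=C(C(=O)NCc2ccc(C)cc2)C(c2ccc(OC)cc2)OC1` gives in this assay 15900 nM.

For the measured compounds named here, compound 3 thus holds the only real number among the three; the other two sit at the limit (the limit of > 100000 nM in this assay, at which 2 of the 3 values shown sit). Going by the values given here, the one measured step, a step that the two limits leave unreadable from compound 1 to compound 2, cannot be sized, as both of its ends are limits.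

Compound 4 `C=CC1=C(C(=O)NCc2ccc(C)cc2)C(c2ccc(OC)c(OC)c2)OC1` is not yet measured. It differs from compound 3 by methoxy in place of hydrogen on an aromatic carbon. Among the compounds with values here, no measured step touches this change directly. The closest guide is that compound 1 and compound 2, which both carry two methoxy groups on that ring, each reach only the limit in this assay, while compound 3, with one methoxy group, gives a number. Compound 4 is therefore expected to land nearer the limit than compound 3, with an expected step of a 3.1-fold higher number from compound 3 to compound 4 (0.50 log units; beyond the scatter) in this assay. Compound 4 is estimated at 50000 nM, in a range from 15000 nM to 200000 nM, with a fair chance that this assay again reports only a limit.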

Compound 4, half-maximal inhibitory concentration: > 100000 nM
Compound 4: a limit, no number; the forecaster's own chance of this, stated with the estimate: 40%; at least 2.0-fold (0.30 log units) between middle value and limit.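

In this assay, methoxy in place of hydrogen on an aromatic carbon, ortho to a methoxy group, gives an at least 6.2-fold higher number from compound 3 to compound 4 (0.79 log units; beyond the scatter), so this small change at this one position is enough to lose the measurable activity of compound 3. The earlier compounds shown here could not show this on their own, as compound 1 and compound 2 differ from compound 3 in more than one place, whereas compound 4 keeps the amide side of compound 3 and changes only the ring substitution, which ties the drop to the added methoxy group. The steps linking compound 4 to compound 1 and compound 2 cannot be read, as both ends of each are limits, and all three compounds with the second methoxy group now share that ceiling, with no compound shown going against this: the limit of > 100000 nM in this assay, at which 3 of the 4 values shown sit.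

On these data alone, how far the true value of compound 4 lies past that limit stays unknown, so the step has a lower bound but no upper one. Also open, as far as these compounds go, is whether this position rejects methoxy in particular or any added group, which a hydroxy group, a fluorine atom or the longer ethoxy chain at the same carbon could begin to separate.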